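This account rests on a few compounds, and the source may have more. Where it says the series, first, only, none or still open, it means among the compounds named here.

Three measured compounds share one core and differ only in the aryl group carried on an aromatic nitrogen. Compound 1 `Cc1ccccc1-n1nncc1CN1C(=O)C2(C(C#N)=C(N)Oc3c(N)cc4nc5ccccc5nc4c32)c2ccccc21` bears a 2-methylphenyl there. In an ADME assay on L02 cells (Homo sapiens) for antiproliferative activity, read by MTT assay, with a stated time of 48 h (a higher number here means a weaker inhibitor, a lower number a stronger inhibitor), compound 1 gives > 50000 nM, which is a limit of the assay rather than a number. Compound 2 `CCOc1ccc(-n2nncc2CN2C(=O)C3(C(C#N)=C(N)Oc4c(N)cc5nc6ccccc6nc5c43)c3ccccc32)cc1` carries a 4-ethoxyphenyl in its place. In this assay compound 2 likewise reaches only a limit, > 50000 nM. Compound 3 `Cc1ccc(-n2nncc2CN2C(=O)C3(C(C#N)=C(N)Oc4c(N)cc5nc6ccccc6nc5c43)c3ccccc32)cc1C` carries a 3,4-dimethylphenyl. In this assay compound 3 also stops at a limit, > 50000 nM, so its standing among the three is simply that all sit together at the limit of > 50000 nM in this assay, at which 3 of the 3 values shown sit. The steps a step that the two limits leave unreadable from compound 1 to compound 2, a step that the two limits leave unreadable from compound 1 to compound 3 and a step that the two limits leave unreadable from compound 2 to compound 3 are all unreadable, because each pair sits at the limit of > 50000 nM in this assay, at which 3 of the 3 values shown sit. Compound 4 `CCc1cccc(C)c1-n1nncc1CN1C(=O)C2(C(C#N)=C(N)Oc3c(N)cc4nc5ccccc5nc4c32)c2ccccc21` is the next member: 2-ethyl-6-methylphenyl in place of 3,4-dimethylphenyl on an aromatic nitrogen. All three measured steps bear on this change, since each exchanges one aryl group for another at the same nitrogen, and none of them showed a readable size. The expectation for a step that the limit leaves unreadable from compound 3 to compound 4 is therefore no step beyond the scatter, and compound 4 is expected to return a limit once more. The estimate for compound 4 in this assay is 80000 nM, with a range from 30000 nM to 300000 nM.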

Compound 4, half-maximal inhibitory concentration: > 50000 nM
Compound 4: no number, only a limit; the forecaster's own chance of this, stated with the estimate: 85%; the middle value is on the limit's open side.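

Compound 4 also stops at a limit in this assay, so none of its steps to compound 1, compound 2 and compound 3 can be read: the limit of > 50000 nM in this assay, at which 4 of the 4 values shown sit. The four compounds leave open whether any of these aryl groups on the aromatic nitrogen differs from another in this assay, and how large such a difference would be.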